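Exocyclic methylidene variant of compound 3 at the EP3 receptor

The source may hold more compounds than are shown below. What is called first, only, known or untested is meant among the compounds shown, and "the series" means these compounds.

Compounds measured so far:
compound 1 `CC(C)C(CC1C(=O)NC(=O)N1C)c1ccc(-c2ccc3cccc(F)c3c2)[nH]c1=O`: 17 nM
compound 2 `CC(C)C(c1ccc(-c2ccc3cccc(F)c3c2)[nH]c1=O)C1NC(=O)NC1=O`: 50 nM
compound 3 `CC(C)C(c1ccc(-c2ccc3cccc(F)c3c2)[nH]c1=O)C1SC(=O)NC1=O`: 25 nM

All three numbers come from an assay on membranes from Chem-1 cells for displacement of a labelled ligand from prostaglandin E2 receptor EP3 subtype (Homo sapiens), read by scintillation counting, with a stated time of 2 h; a higher number here means a weaker inhibitor, a lower number a stronger inhibitor. Compound 3 has the second highest of the three numbers, and its gaps to both neighbours are small: the step of a 1.5-fold higher number from compound 1 to compound 3 (0.17 log units; within the scatter) and the step of a 2.0-fold lower number from compound 2 to compound 3 (0.30 log units; within the scatter) are each within the scatter. Within the data shown here, only the step of a 2.9-fold higher number from compound 1 to compound 2 (0.47 log units; beyond the scatter) lies beyond it.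

Compound 4 `CC(C)C(/C=C1\SC(=O)NC1=O)c1ccc(-c2ccc3cccc(F)c3c2)[nH]c1=O` has not yet been measured. Its change from compound 3 is a group of 8 heavy atoms (4 carbon, 1 nitrogen, 2 oxygen, 1 sulfur; one five-membered non-aromatic ring with 2 hetero atoms) in place of a group of 7 heavy atoms (3 carbon, 1 nitrogen, 2 oxygen, 1 sulfur; one five-membered non-aromatic ring with 2 hetero atoms), on a saturated chain carbon bound to an aromatic carbon and a saturated chain carbon. In words, the ring on the saturated chain carbon is kept but now hangs from one further carbon through a double bond outside the ring.

The measured steps that bear on this are those where the ring attached to the same chain carbon was varied: the step from compound 1 to compound 3 and the step from compound 2 to compound 3 stayed within the scatter, and the largest of the three, the step from compound 1 to compound 2, was only modest. Among the measured compounds shown here, no measured step adds a carbon with a double bond in this position, so the expectation rests on the general insensitivity of this assay to changes at that carbon. Compound 4 is therefore expected to show a step of a 1.2-fold higher number from compound 3 to compound 4 (0.08 log units; within the scatter) that stays within the scatter. For compound 4 the estimated value in this assay is 30 nM, with a range from 12 nM to 80 nM.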

Compound 4, inhibition constant: 13 nM
The estimate for compound 4 lay 2.3-fold (0.36 log units) above the measured number, within the range that was stated.
By their numbers in this assay, from the lowest: compounds 4, 1, 3 and 2 (each within the scatter of the next, the first and the last beyond it).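

At the saturated chain carbon, the 2,4-dioxo-1,3-thiazolidin-5-yl ring can hang from one further carbon through a double bond outside the ring and stay within the scatter in this assay, with a 1.9-fold lower number from compound 3 to compound 4 (0.28 log units; within the scatter). The new group also stays within the scatter of the larger group in compound 1, with a 1.3-fold lower number from compound 1 to compound 4 (0.12 log units; within the scatter), whereas a 3.8-fold lower number from compound 2 to compound 4 (0.59 log units; beyond the scatter) is the largest step in the set and lies beyond it. No measurement shown accounts for these numbers or links them to any property of the group.

On these data alone, whether a 2,4-dioxo-1,3-thiazolidin-5-ylmethyl group, which has the further carbon without the double bond outside the ring, would match compound 4 remains open. So does the outcome for a longer chain carrying the ring, or for a carboxylic acid in its place.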